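A few compounds are considered here, and "the series" means these few. Any claim that something is new, unique, unknown or untested is made for them only; others in the source may bear on it.

Measured so far in an ADME assay on LLC-MK2 cells (Macaca mulatta) for cytotoxicity, read by spectrophotometry and crystal violet staining, with a stated time of 4 days; a lower number here means that less compound is tolerated, a higher number that more compound is tolerated:
compound 1 `CNS(=O)(=O)c1cccc(NC(=O)c2cc(-c3cccs3)nc3c2cnn3C(C)C)c1`: 25000 nM
compound 2 `CC(C)n1ncc2c(C(=O)Nc3ccccc3F)cc(-c3ccncc3)nc21`: 45000 nM

Compound 1 gives the lowest of the two numbers measured in this assay; compound 2, with 45000 nM, sits within the scatter of it, so the two are not separated and no order can be read between them. Compound 3 `CC(C)n1ncc2c(C(=O)Nc3cccc(S(N)(=O)=O)c3)cc(-c3cccs3)nc21` has not yet been measured. It differs from compound 1 in one place: hydrogen in place of methyl on a sulfonamide nitrogen. Within the data shown here, no measured pair shares this change, so its size is not known from the numbers at hand. Among the measured compounds shown here, nothing in the two values so far points to a step beyond the scatter in this assay in either direction, and the expected step is no change at the digits printed from compound 1 to compound 3 (within the scatter). Compound 3 is therefore estimated to give 25000 nM in this assay, with a range from 10000 nM to 60000 nM.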

Compound 3, half-maximal cytotoxic concentration: 25000 nM
Compound 3: the middle estimate sits on the measured number at the digits printed; the measured number falls inside the stated range.
By their numbers in this assay, from the lowest: compounds 1, 3 and 2 (each within the scatter of the next).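

Hydrogen in place of methyl on the sulfonamide nitrogen gives no change at the digits printed from compound 1 to compound 3 (within the scatter) in this assay. Among these compounds, this is the first comparison that isolates a single position, since the two earlier compounds differ in more than one place. Within the core of compound 1, the methylsulfamoyl and sulfamoyl forms are therefore not separated in this read-out, and the methyl is not required for a value in this range. No measured evidence at hand offers an explanation for this result.

Going by these compounds, the reading rests on one pair on one core, so it remains unknown whether the same change would give the same result with other groups elsewhere on the molecule. Also open, on these data alone, is how a longer chain, such as propyl, or an amine-bearing chain on this nitrogen would read in this assay.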